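A few compounds are considered here, and "the series" means these few. Any claim that something is new, unique, unknown or untested is made for them only; others in the source may bear on it.

Measured compounds:
compound 1 `O=C(O)Cc1sc(C(c2ccccc2)c2ccc(F)cc2)nc1-c1ccc(Cl)cc1`, 36 nM in an in vitro functional assay on HEK285-7 cells for antagonist activity at prostaglandin D2 receptor 2 (Homo sapiens), read by BRET and beta-arrestin recruitment; a lower number here means a stronger inhibitor, a higher number a weaker inhibitor
compound 2 `O=C(O)Cc1sc(C(c2ccc(F)cc2)c2ccc(F)cc2)nc1-c1cccc(F)c1`, 18 nM in this assay

Compound 2 has the lowest of the two numbers in this assay, with compound 1 as its nearest neighbour; the gap between the two lies within the scatter, so no order between them can be read from these figures, and both are simply inhibitors in the same range.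

Compound 3 `NS(=O)(=O)c1ccc(-c2nc(C(c3ccc(F)cc3)c3ccc(F)cc3)sc2CC(=O)O)cc1` has not been measured. It differs from compound 2 in one place: 4-sulfamoylphenyl in place of 3-fluorophenyl on an aromatic carbon. The place is an aromatic carbon of the five-membered ring with one nitrogen and one sulfur, next to the ring nitrogen and next to the ring atom that bears the carboxymethyl group. For the measured compounds named here, no measured pair shows a change of this kind, so the size and direction of the step cannot be taken from the data; the change is larger than the one between compound 1 and compound 2.

The step of a 1.7-fold higher number from compound 2 to compound 3 (0.22 log units; within the scatter) is therefore expected to be small, with a wide range. Compound 3 is estimated at 30 nM in this assay, between 8 nM and 120 nM.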

Compound 3, half-maximal inhibitory concentration: > 100000 nM
Compound 3 gave a limit, no number; the forecaster's own chance of this, stated with the estimate: 5%; at least 3300-fold (3.52 log units) between middle value and limit.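

In this assay compound 3 gives > 100000 nM, which is a limit of the assay and not a number. For the compounds shown here, at this aromatic carbon, next to the ring nitrogen, 4-sulfamoylphenyl in place of 3-fluorophenyl gives an at least 5500-fold higher number from compound 2 to compound 3 (3.74 log units; beyond the scatter), the first step that can be read at one place, and a large one. Compound 1 and compound 2 alone gave no sign of this, but the position is now seen to be far from indifferent to the group it carries, and the step is bounded from one side only: the limit of > 100000 nM in this assay, at which 1 of the 3 values shown sits.

The compounds shown leave open whether the loss of inhibition belongs to the sulfamoyl group itself or to where it sits on the phenyl ring, and whether any other group on that ring would behave in the same way. As far as these compounds go, a 3-sulfamoylphenyl, a 4-methylsulfonylphenyl or a 4-carboxyphenyl group at this carbon would separate these readings, and the effect of replacing the aryl group with an amine or a short alkyl chain also remains open.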